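Replacing a ring hydrogen with an oxygen atom

A few compounds are considered here, and "the series" means these few. Any claim that something is new, unique, unknown or untested is made for them only; others in the source may bear on it.

Measured so far:
compound 1, `CNC(=O)[C@H]1O[C@@H](n2cnc3c(Nc4ccc5c(c4)C(C)(C)NC5(C)C)ncnc32)[C@H](O)[C@@H]1O`: 70 nM
compound 2, `CC1(C)c2ccc(CNC3NC=Nc4c3ncn4[C@@H]3O[C@H](CO)[C@@H](O)[C@H]3O)cc2C(C)(C)N1[O]`: 280 nM
compound 3, `CNC(=O)[C@H]1O[C@@H](n2cnc3c(NCc4ccc5c(c4)C(C)(C)N([O])C5(C)C)ncnc32)[C@H](O)[C@@H]1O`: 320 nM

These three compounds were compared in an assay on isolated protein for displacement of a labelled ligand from adenosine receptor A3 (Homo sapiens); on this read-out higher numbers stand for weaker inhibition and lower numbers for stronger inhibition. Compound 1 gives the lowest number of the three, 70 nM. The nearest value belongs to compound 2 with 280 nM, and the furthest to compound 3 with 320 nM; both of these lie above compound 1 by more than the usual scatter of this assay, so compound 1 is the strongest binder among the measured set. For the measured compounds named here, compounds 2 and 3 differ from compound 1 in more than one place, so no single step between measured compounds is available.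

The unmeasured compound 4, `CNC(=O)[C@H]1O[C@@H](n2cnc3c(Nc4ccc5c(c4)C(C)(C)N([O])C5(C)C)ncnc32)[C@H](O)[C@@H]1O`, differs from compound 1 in exactly one place: one oxygen atom in place of a hydrogen atom, on an amine nitrogen in a ring. In words, one oxygen atom takes the place of a hydrogen atom on an amine nitrogen in a ring. Nothing measured here isolates what this exchange does on its own; compounds 2 and 3 both carry that oxygen and give similar numbers to each other, but they also carry a different linker, so their values cannot be read as the effect of the oxygen alone. The step from compound 1 to compound 4 is therefore expected to be small, a 1.7-fold higher number from compound 1 to compound 4 (0.23 log units; within the scatter), and may well fall within the scatter. Compound 4 is estimated to give 120 nM in this assay, with a likely range from 40 nM to 400 nM.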

Compound 4, inhibition constant: 530 nM
Compound 4: middle estimate off by 4.4-fold (0.65 log units), on the low side; the whole stated range lies below it.
By their numbers in this assay, from the lowest: compound 1; then compounds 2, 3 and 4 (each within the scatter of the next).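

In this assay, the exchange of a hydrogen atom for one oxygen atom on the amine nitrogen in a ring now has a size of its own: a 7.6-fold higher number from compound 1 to compound 4 (0.88 log units; beyond the scatter), and this step lies beyond the usual scatter. This position is therefore sensitive to the change, since adding this single atom, with the rest of compound 1 kept as it is, is enough to weaken inhibition. The earlier compounds shown here could not show this, as each of them differs from compound 1 in more than one place. Nothing available explains why this one oxygen atom has this effect.

Still open, from the compounds shown here alone, is how other groups on the same nitrogen would compare, such as a methyl group or an acetyl group, and so whether the loss is particular to oxygen or follows from replacing the hydrogen with any atom. Going by these compounds, it is also open whether the same exchange gives a step of similar size in a compound with the methylene linker of compound 3.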